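Series notes: from 4-chlorophenyl to 3,4-dichlorophenyl

This account rests on a few compounds, and the source may have more. Where it says the series, first, only, none or still open, it means among the compounds named here.

Measured so far:
compound 1 `CCOC(=O)c1cc2ccc(OCCCn3cc(CNC(=O)CCCCC4CCSS4)nn3)cc2oc1=O` — 36.1%
compound 2 `O=C(CCCCC1CCSS1)NCc1cn(CCCOc2ccc3cc(-c4ccc(Cl)cc4)c(=O)oc3c2)nn1` — 67.8%

In a functional assay on PC-12 cells (Rattus norvegicus) for cytotoxicity, read by MTT assay, with stated times of 3 h and 2 h, tested at 10 uM (on this read-out higher numbers stand for a stronger effect at the one concentration tested and lower numbers for a weaker effect), compound 1 gives 36.1% and compound 2 gives 67.8%; compound 2 thus stands highest of the two numbers, with a number 31.7 percentage points higher from compound 1 to compound 2 (beyond the scatter).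

Compound 3 `O=C(CCCCC1CCSS1)NCc1cn(CCCOc2ccc3cc(-c4ccc(Cl)c(Cl)c4)c(=O)oc3c2)nn1` differs from compound 2 by chloro in place of hydrogen on an aromatic carbon. Among the compounds with values here, no measured step matches this change: the single step, a number 31.7 percentage points higher from compound 1 to compound 2 (beyond the scatter), swaps a different group and so bears only loosely on it. A step within the scatter is therefore expected, a number 2.2 percentage points higher from compound 2 to compound 3 (within the scatter). Compound 3 is estimated at 70%, with a range from 50% to 88%.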

Compound 3, a percentage reported as activity, at one concentration (the size of the read-out at that concentration, not a potency): 49.6%
Compound 3: the middle estimate sits 20.4 percentage points above what was measured, outside the stated range (below it).
By their numbers in this assay, from the lowest: compound 1; then compound 3; then compound 2.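

In this assay, going from 4-chlorophenyl to 3,4-dichlorophenyl gives a number 18.2 percentage points lower from compound 2 to compound 3 (beyond the scatter), so the read-out responds to substitution on the phenyl group itself, not only to the replacement of ethoxycarbonyl. Relative to ethoxycarbonyl, 3,4-dichlorophenyl keeps a gain, a number 13.5 percentage points higher from compound 1 to compound 3 (beyond the scatter), though a smaller one than a number 31.7 percentage points higher from compound 1 to compound 2 (beyond the scatter). Nothing on hand bears on what lies behind the drop.

Still open, from the compounds shown here alone, is whether a lone chloro group at the added place, without the 4-chloro group, reads like compound 3. Also open, going by these compounds, is how a methoxy or amino group on this phenyl group would read.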